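Working notes: next step in the series, compound 3

This account rests on a few compounds, and the source may have more. Where it says the series, first, only, none or still open, it means among the compounds named here.

Measured so far:
compound 1 `CCOC(=O)C1=C(Nc2ccccc2)S/C(=C\c2ccc(O)c(O)c2)C1=O` — 38.1%
compound 2 `CCOC(=O)C1=C(Nc2ccccc2)S/C(=C\c2ccc[nH]2)C1=O` — 18.3%

In a functional assay on MCF7 cells (Homo sapiens) for inhibition, read by MTT assay, with a stated time of 72 h, tested at 10 uM (on this read-out higher numbers stand for more inhibition at the one concentration tested (going by the name of the read-out) and lower numbers for less inhibition), compound 1 gives 38.1%, and compound 2 gives 18.3%. Among the measured compounds shown here, compound 2 stands lowest of the two numbers; the only measured step, a number 19.8 percentage points lower from compound 1 to compound 2 (beyond the scatter), leads to it. Compound 3 `CCOC(=O)C1=C(Nc2ccccc2)S/C(=C\c2cc[nH]c2)C1=O` differs from compound 2 in a single place: 1H-pyrrol-3-yl in place of 1H-pyrrol-2-yl on a double-bonded chain carbon bound to a double-bonded ring carbon. For the measured compounds named here, no measured step bears on this change directly: the one step recorded exchanges the whole ring for another, whereas here the two compounds have the same atoms joined differently, so no direction can be read from it. In the absence of a bearing step, a change within the usual scatter is expected, a number 1.7 percentage points higher from compound 2 to compound 3 (within the scatter), with the range kept wide on both sides. The estimate for compound 3 in this assay is 20%, with a range from 8% to 35%.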

Compound 3, a percentage reported as inhibition, at one concentration (the size of the read-out at that concentration, not a potency): < 10%
Compound 3: only a limit was reported (the forecaster's own chance of this, stated with the estimate: 0%); at least 10 percentage points between middle value and limit.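

In this assay compound 3 gives < 10%, which is a limit of the assay and not a number. With the same atoms joined differently, 1H-pyrrol-3-yl in place of 1H-pyrrol-2-yl gives a number at least 8.3 percentage points lower from compound 2 to compound 3 (that floor lies within the scatter), so no firm order between the two pyrrole groups at this place can be claimed. The exchange of 3,4-dihydroxyphenyl for 1H-pyrrol-3-yl is clearer, with a number at least 28.1 percentage points lower from compound 1 to compound 3 (beyond the scatter), and it shows that a second pyrrole attachment at this place also falls short of compound 1.

From the compounds shown here alone, whether a plain phenyl, a 4-methoxyphenyl or a pyridin-3-yl group on the same chain carbon would side with compound 1 or with the pyrroles remains open. How far compound 3 lies under its limit also remains open: the limit of < 10% in this assay, at which 1 of the 3 values shown sits.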